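Tolerated Concentration Stays at the Assay Ceiling

The compounds below may be only part of what the source reports. "The series", "measured", "known", "first", "only" and "open" are said of these compounds alone.

compound 1 `CCCCCCCCOc1nc(N)nc2c1ncn2/C=C1/CC1(CO)CO` — > 300000 nM
compound 2 `Nc1nc(NC2CCCC2)c2ncn(/C=C3/CC3(CO)CO)c2n1` — > 300000 nM

In an ADME assay on HFF cells (Homo sapiens) for cytotoxicity, with a stated time of 8 days (a higher number here means that more compound is tolerated, a lower number that less compound is tolerated), compound 1 gives only a limit of the assay, not a number. The value for compound 2 is likewise a limit. Both measured values sit at the same ceiling (the limit of > 300000 nM in this assay, at which 2 of the 2 values shown sit), so the size of the step that the two limits leave unreadable from compound 1 to compound 2 cannot be read. Compound 3 `Nc1nc(SCc2ccccc2)c2ncn(/C=C3/CC3(CO)CO)c2n1` differs from compound 1 by benzylsulfanyl in place of octyloxy on an aromatic carbon. For the measured compounds named here, the one measured step concerns the same place but a different entering group, and its size is unreadable, so no measured step gives a usable size for the change to benzylsulfanyl. What the two limits do show is that neither compound 1 nor compound 2 reached a measurable toxic concentration. Compound 3 is therefore expected to remain at about the same level, a step of a number no higher from compound 1 to compound 3 (the limit leaves the size open), most likely reported again as a limit. The estimate for compound 3 is 300000 nM, with a range from 100000 nM to 900000 nM.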

Compound 3, half-maximal cytotoxic concentration: > 300000 nM
Compound 3 gave a limit, no number; the forecaster's own chance of this, stated with the estimate: 80%; the middle value sits exactly at the limit.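

For the compounds shown here, compound 3 also gives a limit rather than a number, so no step among compound 1, compound 2 and compound 3 can be read: the limit of > 300000 nM in this assay, at which 3 of the 3 values shown sit. Left open is whether octyloxy, cyclopentylamino and benzylsulfanyl differ at all in this assay, and what concentration of each compound would prove toxic.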